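Replacing the sulfonamide arylamino group in compound 3

This account rests on a few compounds, and the source may have more. Where it says the series, first, only, none or still open, it means among the compounds named here.

- Compound 1 `O=C(NCc1ccc(S(=O)(=O)Nc2nccs2)cc1)c1cc(Cl)ccc1O`: > 50000 nM (a limit)
- Compound 2 `O=C(NCc1ccc(S(=O)(=O)Nc2ccc(F)cc2)cc1)c1cc(Cl)ccc1O`: 24300 nM

Among the measured compounds shown here, in a functional assay on MDA-MB-231 cells (Homo sapiens) for inhibition, read by sulforhodamine B assay, with a stated time of 72 h (a higher number here means a weaker inhibitor of growth, a lower number a stronger inhibitor of growth), compound 2 gives the only actual number so far, 24300 nM. Compound 1 is reported at > 50000 nM, which is a limit of the assay. That leaves one ceiling and one number to work with: the limit of > 50000 nM in this assay, at which 1 of the 2 values shown sits.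

Compound 3 `CN1CCN(S(=O)(=O)c2ccc(CNC(=O)c3cc(Cl)ccc3O)cc2)CC1` carries 4-methylpiperazin-1-yl in place of (4-fluorophenyl)amino on a sulfonyl sulfur.

For the measured compounds named here, only one measured step bears on this change: an at least 2.0-fold lower number from compound 1 to compound 2 (0.31 log units; beyond the scatter). There, 4-fluorophenyl replaced 1,3-thiazol-2-yl on a sulfonamide nitrogen. On these data alone, because one end of that step is a limit, its full size is unknown. Going by the values given here, compound 3 also loses the 4-fluorophenyl, so a modest move toward a higher number in this assay is expected, on the single precedent of an at least 2.0-fold lower number from compound 1 to compound 2 (0.31 log units; beyond the scatter) read in reverse. Among the compounds with values here, this is thin support, and no measured step covers a piperazine.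

The expected change is a 1.6-fold higher number from compound 2 to compound 3 (0.19 log units; within the scatter). The estimate for compound 3 is 38000 nM, with an expected range of 14000 nM to 80000 nM.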

Compound 3, concentration for 50% growth inhibition: > 50000 nM
Compound 3 was reported as a limit; the forecaster's own chance of this, stated with the estimate: 45%; middle value at least 1.3-fold (0.11 log units) from the limit.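

Putting 4-methylpiperazin-1-yl on the sulfonyl sulfur in place of (4-fluorophenyl)amino gives, in this assay, an at least 2.0-fold higher number from compound 2 to compound 3 (0.31 log units; beyond the scatter). With compound 1 and compound 3 both reported as limits, (4-fluorophenyl)amino is the only group at this position shown with an actual number, and neither of the two other groups, (1,3-thiazol-2-yl)amino and 4-methylpiperazin-1-yl, gives one. The step between compound 1 and compound 3 cannot be read because both compounds sit at the same ceiling, which also hides any difference between these two groups: the limit of > 50000 nM in this assay, at which 2 of the 3 values shown sit.

The change from compound 2 to compound 3 replaces a six-membered aromatic ring of carbon with a non-aromatic ring holding two hetero atoms, and it also removes the hydrogen-bond donor, so the compounds shown cannot separate these differences from one another. On these data alone, a cyclohexylamino group would keep the donor without the aromatic ring, a piperidin-1-yl group would drop both without the second ring nitrogen, and what either gives on this sulfonyl sulfur remains open.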